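This account rests on a few compounds, and the source may have more. Where it says the series, first, only, none or still open, it means among the compounds named here.

Measured so far, in a functional assay on MIA PaCa-2 cells (Homo sapiens) for inhibition, read by MTT assay, with a stated time of 72 h; on this read-out higher numbers stand for weaker inhibition of growth and lower numbers for stronger inhibition of growth:

Compound 1, `O=S(=O)(NCCCNCc1ccc(Cl)cc1)c1cc(C(F)(F)F)cc(C(F)(F)F)c1`: 2800 nM
Compound 2, `COc1cccc(CNCCCNS(=O)(=O)c2cc(C(F)(F)F)cc(C(F)(F)F)c2)c1`: 3400 nM
Compound 3, `O=S(=O)(NCCCNCc1ccc(C(F)(F)F)cc1)c1cc(C(F)(F)F)cc(C(F)(F)F)c1`: 2500 nM

All three share the same core and differ only in the group on a saturated chain carbon bound to an amine nitrogen. Their numbers in this assay sit close together: the step of a 1.2-fold higher number from compound 1 to compound 2 (0.08 log units; within the scatter), the step of a 1.1-fold lower number from compound 1 to compound 3 (0.05 log units; within the scatter) and the step of a 1.4-fold lower number from compound 2 to compound 3 (0.13 log units; within the scatter) each stay within the scatter, so none of the three can be called stronger or weaker than the others. Compound 3 has the lowest number of the three, but only by margins that the scatter covers.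

Compound 4, `O=S(=O)(NCCCNCC1COc2ccccc2O1)c1cc(C(F)(F)F)cc(C(F)(F)F)c1`, is not yet measured. It carries the change (2,3-dihydro-1,4-benzodioxin-2-yl in place of 4-(trifluoromethyl)phenyl on a saturated chain carbon bound to an amine nitrogen); cut one bond further out, the same difference reads 4-(trifluoromethyl)benzyl to (2,3-dihydro-1,4-benzodioxin-2-yl)methyl. The three measured steps, which all swap the group at this same place, bear on it, and all were small. The entering group is of a different kind from the groups tried so far, so the outcome is less certain, yet on the evidence given no step beyond the scatter is expected: the step of a 1.2-fold higher number from compound 3 to compound 4 (0.08 log units; within the scatter) is the estimate here. Compound 4 is therefore expected to give about 3000 nM in this assay, with a range from 1200 nM to 8000 nM.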

Compound 4, concentration for 50% growth inhibition: 2600 nM
The estimate for compound 4 lay 1.2-fold (0.06 log units) above the measured number, and the stated range covers the measured number.
By their numbers in this assay, from the lowest: compounds 3, 4, 1 and 2 (each within the scatter of the next).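

In this assay, 2,3-dihydro-1,4-benzodioxin-2-yl adds a non-aromatic ring with 2 hetero atoms and brings 2 hydrogen-bond acceptors where 4-(trifluoromethyl)phenyl has 0, yet the steps of a 1.0-fold higher number from compound 3 to compound 4 (0.02 log units; within the scatter) and a 1.3-fold lower number from compound 2 to compound 4 (0.12 log units; within the scatter) and a 1.1-fold lower number from compound 1 to compound 4 (0.03 log units; within the scatter) all stay small. The earlier compounds shown here varied only the substituent on a single aromatic ring, whereas this result shows that a group of a different kind at this place, on a saturated chain carbon bound to an amine nitrogen, also gives a number that cannot be told apart from the other three. Nothing in the information given accounts for this lack of change.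

The four compounds therefore leave open whether any group at this place can move the number beyond the scatter, and a carboxylic acid or a dimethylamino group on the aromatic ring would be a sharper test than another neutral ring. They also leave open what a longer chain in the shared core would do, with the rest of the structure kept the same.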